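Amide exchange on the shared core: morpholin-4-yl to benzylamino

The compounds below may be only part of what the source reports. "The series", "measured", "known", "first", "only" and "open" are said of these compounds alone.

In a functional assay on PC-3 cells (Homo sapiens) for inhibition, read by sulforhodamine B assay, with a stated time of 72 h (on this read-out lower numbers stand for stronger inhibition and higher numbers for weaker inhibition), compound 3 (`Nc1sc(-c2ccc(Cl)cc2)c(-c2ccc(Cl)cc2)c1C(=O)N1CCOCC1`) gives 11700 nM. Compound 1 (`Nc1sc(-c2ccc(Cl)cc2)c(-c2ccc(Cl)cc2)c1C(=O)N1CCCCC1`) gives 14300 nM, level with compound 3 within the scatter. Compound 2 (`CCOC(=O)Nc1sc(-c2ccc(Cl)cc2)c(-c2ccc(Cl)cc2)c1C(=O)NC1CC1`) gives 27600 nM, a higher number than that of compound 3, with a gap beyond the scatter.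

The next structure is compound 4 (`Nc1sc(-c2ccc(Cl)cc2)c(-c2ccc(Cl)cc2)c1C(=O)NCc1ccccc1`), which has benzylamino in place of morpholin-4-yl on a carbonyl carbon.

Going by the values given here, only one measured step changes this position alone. It is a 1.2-fold lower number from compound 1 to compound 3 (0.09 log units; within the scatter), and the exchange of piperidin-1-yl for morpholin-4-yl therefore moves nothing measurable in this assay. Among the compounds with values here, compound 2 also has a hydrogen on the amide nitrogen, as compound 4 does, but it differs from compound 3 in a second place as well, so it gives no clean step. Within the data shown here, no measured compound carries benzylamino, which leaves the range wide and tilted towards higher numbers, in the direction of the value of compound 2.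

No change beyond the scatter is expected, and the expected step is a 1.3-fold higher number from compound 3 to compound 4 (0.11 log units; within the scatter). For compound 4 the estimated value is 15000 nM, with an expected range of 6000 nM to 35000 nM.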

Compound 4, half-maximal inhibitory concentration: 31800 nM
Estimate against measurement, compound 4: 2.1-fold (0.33 log units) below, within the range that was stated.
By their numbers in this assay, from the lowest: compounds 3, 1, 2 and 4 (each within the scatter of the next, the first and the last beyond it).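

In this assay, the position on the carbonyl carbon is not indifferent to the group it carries: morpholin-4-yl and piperidin-1-yl stand level, but benzylamino gives a 2.7-fold higher number from compound 3 to compound 4 (0.43 log units; beyond the scatter) and a 2.2-fold higher number from compound 1 to compound 4 (0.35 log units; beyond the scatter). Both steps run towards weaker inhibition and lie beyond the scatter, though both are modest, so the shared core tolerates this exchange with only a limited loss. The exchange replaces a non-aromatic ring with an aromatic ring of carbon only and also introduces the amide hydrogen, and the available information cannot assign the step to either change or give a reason for it.

Still open, from the compounds shown here alone, is how a small open-chain group such as ethylamino would read on the same core, since it would keep the amide hydrogen without the aromatic ring. Also open, going by these compounds, are a longer chain such as 2-phenylethylamino, which would show how this position responds to moving the aromatic ring further out, and a piperazin-1-yl ring, which would extend the ring series with a second ring nitrogen.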